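A few compounds are considered here, and "the series" means these few. Any claim that something is new, unique, unknown or untested is made for them only; others in the source may bear on it.

Compound 1 `CC(O)(CSc1cccc(C(F)(F)F)c1)C(=O)Nc1cccc(S(F)(F)(F)(F)F)c1` in a functional assay on DU-145 cells (Homo sapiens) for antiproliferative activity, read by propidium iodide staining, with a stated time of 96 h (on this read-out lower numbers stand for stronger inhibition and higher numbers for weaker inhibition), gives 19100 nM. Compound 2 `CC(O)(CSc1ccccc1C(F)(F)F)C(=O)Nc1cccc(S(F)(F)(F)(F)F)c1` in this assay gives 15800 nM; here 2-(trifluoromethyl)phenyl in place of 3-(trifluoromethyl)phenyl on a sulfur made a step of a 1.2-fold lower number from compound 1 to compound 2 (0.08 log units; within the scatter). Compound 3 `CC(O)(CS(=O)(=O)c1cccc(C(F)(F)F)c1)C(=O)Nc1ccc(S(F)(F)(F)(F)F)cc1` in this assay gives 31900 nM; how its core differs from that of compound 1 is not broken down here. Compound 4 `CC(O)(CS(=O)(=O)c1ccccc1C(F)(F)F)C(=O)Nc1ccc(S(F)(F)(F)(F)F)cc1` carries the same kind of change, 2-(trifluoromethyl)phenyl in place of 3-(trifluoromethyl)phenyl on a sulfonyl sulfur, the place being a sulfonyl sulfur rather than a sulfur. The step from compound 3 to compound 4 is expected to be small, a 1.2-fold lower number from compound 3 to compound 4 (0.09 log units; within the scatter), because the same change gave a 1.2-fold lower number from compound 1 to compound 2 (0.08 log units; within the scatter). For compound 4 in this assay the expected value is 26000 nM, estimated to lie between 12000 nM and 56000 nM.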

Compound 4, half-maximal inhibitory concentration: 29400 nM
The estimate for compound 4 lay 1.1-fold (0.05 log units) below the measured number; measured number inside the range.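

In this assay, putting 2-(trifluoromethyl)phenyl in place of 3-(trifluoromethyl)phenyl on a sulfonyl sulfur gave a 1.1-fold lower number from compound 3 to compound 4 (0.04 log units; within the scatter). Among the compounds shown here, the change therefore stayed small on the core of compound 3, as it had on the core of compound 1, and the two steps agree: the same change on two cores in this assay, a 1.2-fold lower number (0.08 log units; within the scatter) from compound 1 to compound 2 and a 1.1-fold lower number (0.04 log units; within the scatter) from compound 3 to compound 4, 1.1-fold (0.05 log units) apart, within the scatter of two such steps This shows only that the change carried over as a step too small to read on these two cores; it does not show that the change has any real effect, or that it would stay this small on a third core.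

The compounds shown leave open whether a larger step would appear with a different group in place of the trifluoromethyl, such as an amine or a carboxylic acid.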